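Adding a Second Methoxy Group: Expected Effect on Cell Growth

The compounds below may be only part of what the source reports. "The series", "measured", "known", "first", "only" and "open" are said of these compounds alone.

Compound 1 `COc1ccc(-c2nc(C)c(C(=O)CSc3nc(-c4ccc(OC)c(OC)c4)c(C#N)c(=O)[nH]3)s2)cc1`: 81.2%
Compound 2 `COc1ccc(-c2nc(SCC(=O)c3sc(-c4ccc(Cl)cc4)nc3C)[nH]c(=O)c2C#N)cc1`: 92.1%

In a functional assay on U-87MG ATCC cells for antiproliferative activity against U-87 MG (Homo sapiens), read by MTT assay, with a stated time of 48 h, tested at 5 uM (a lower number here means a stronger effect, a higher number a weaker effect of the compound at the concentration tested), compound 2 gives the higher of the two numbers, and the gap from compound 1 lies beyond the usual scatter. Compound 3 `COc1ccc(-c2nc(SCC(=O)c3sc(-c4ccc(Cl)cc4)nc3C)[nH]c(=O)c2C#N)cc1OC` is not yet measured. It differs from compound 2 by methoxy in place of hydrogen on an aromatic carbon, so that the 4-methoxyphenyl becomes a 3,4-dimethoxyphenyl. Within the data shown here, no step between measured compounds isolates this change. The step of a number 7.1 percentage points lower from compound 2 to compound 3 (within the scatter) is expected to be small, downward if anything, and within the scatter. Compound 3 is therefore estimated at 85%, between 70% and 98%.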

Compound 3, a percentage reported as activity, at one concentration (the size of the read-out at that concentration, not a potency): 93.4%
Compound 3: middle estimate off by 8.4 percentage points, on the low side; low and high end bracket the measured number.
By their numbers in this assay, from the lowest: compound 1; then compounds 2 and 3 (each within the scatter of the next).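

In this assay, methoxy in place of hydrogen, turning the 4-methoxyphenyl into the 3,4-dimethoxyphenyl, gives a number 1.3 percentage points higher from compound 2 to compound 3 (within the scatter), so this position shows no measurable response to this change. Compound 1 and compound 2 differed in two places, but with the 3,4-dimethoxyphenyl held constant, chloro in place of methoxy on the other aromatic ring gives a number 12.2 percentage points higher from compound 1 to compound 3 (beyond the scatter), which places a real difference at that exchange. Nothing available explains either result.

From the compounds shown here alone, whether a hydroxyl or an amine at the new position would also leave the number unchanged remains open.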